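From 2-oxopropyl to 1-carboxy-1-methylethyl on a shared core

The source may report more compounds than this note shows. Statements on the series, on what has been measured and on what is new or still open speak of the compounds shown alone.

Three compounds have been measured so far in a functional assay on the whole organism (trachea) for inhibition, with Cavia porcellus as the target; on this read-out lower numbers stand for an effect already at smaller amounts and higher numbers for an effect only at larger amounts of compound:
- compound 1 `COc1ccccc1OCC1SCCN1C(=O)CSC` gives 21 mg/kg
- compound 2 `COc1ccccc1OCC1SCCN1C(=O)C[S+](C)[O-]` gives 10 mg/kg
- compound 3 `COc1ccccc1OCC1SCCN1C(=O)CC(C)=O` gives 26 mg/kg

Compound 3 stands level with compound 1, as the step of a 1.2-fold higher number from compound 1 to compound 3 (0.09 log units; within the scatter) lies within the scatter. Together they form the upper end of this small set. Compound 2 stands apart from compound 3, and the step of a 2.6-fold higher number from compound 2 to compound 3 (0.41 log units; beyond the scatter) is modest but beyond the scatter.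

The next compound is compound 4 `COc1ccccc1OCC1SCCN1C(=O)C(C)(C)C(=O)O`, which has 1-carboxy-1-methylethyl in place of 2-oxopropyl on a carbonyl carbon. The difference counts as 1-carboxy-1-methylethyl in place of 2-oxopropyl on a carbonyl carbon in full.

All three measured steps bear on this change only loosely, since each alters a small group on a saturated chain carbon bound to a carbonyl carbon. The step of a 2.1-fold lower number from compound 1 to compound 2 (0.32 log units; beyond the scatter) is also modest, so changes of this kind have moved the numbers little. Among the measured compounds shown here, none of the measured compounds carries the entering group, however, and the data give no direction for it. The estimated step of a 1.1-fold lower number from compound 3 to compound 4 (0.03 log units; within the scatter) therefore stays within the scatter, with wide uncertainty. Compound 4 is expected at about 24 mg/kg, within an estimated range from 8 mg/kg to 75 mg/kg in this assay.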

Compound 4, dose for half-maximal effect: 21 mg/kg
Compound 4: the middle estimate sits 1.1-fold (0.06 log units) above what was measured, within the range that was stated.
By their numbers in this assay, from the lowest: compound 2; then compounds 1, 4 and 3 (each within the scatter of the next).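

In this assay, 1-carboxy-1-methylethyl on the carbonyl carbon brings a larger group and a hydrogen-bond donor that 2-oxopropyl lacks, yet a 1.2-fold lower number from compound 3 to compound 4 (0.09 log units; within the scatter) shows that this exchange leaves the read-out within the scatter. The comparison with (methylsulfanyl)methyl reads the same, at no change at the digits printed from compound 1 to compound 4 (within the scatter), so compound 4 stays level with both of these compounds, while a 2.1-fold higher number from compound 2 to compound 4 (0.32 log units; beyond the scatter) shows that the entering group does not match compound 2 and that only compound 2 stands apart among the four. Nothing given here explains why so different a group leaves the number essentially unmoved.

The compounds shown do not separate the carboxy group from the two methyl groups on the carbon that bears it, so it remains open what a methyl ester or an amine in place of the carboxy group would do. From the compounds shown here alone, it also remains open whether a longer chain on the carbonyl carbon would come level with compound 2 at 10 mg/kg or stay with the other three compounds.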